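Para-substituted benzoylguanidines: ethoxy for methyl

The source may hold more compounds than are shown below. What is called first, only, known or untested is meant among the compounds shown, and "the series" means these compounds.

Measured so far:
compound 1 `Cc1ccc(C(=O)NC(=N)NCCCCc2ccccc2)cc1`: 1140 nM
compound 2 `Cc1ccc(C(=O)NC(=N)NCCCCCc2ccccc2)cc1`: 2110 nM
compound 3 `N=C(NCCCCc1ccccc1)NC(=O)c1c(Cl)cccc1Cl`: 5030 nM

In an assay on CHO cells for inhibition of sodium channel protein type 2 subunit alpha (Homo sapiens) (on this read-out higher numbers stand for weaker inhibition and lower numbers for stronger inhibition), compound 1 gives the lowest of the three numbers. Compound 2 lies within the scatter of it, a 1.9-fold higher number from compound 1 to compound 2 (0.27 log units; within the scatter), so the two cannot be ordered. Compound 3 is clearly weaker, a 4.4-fold higher number from compound 1 to compound 3 (0.64 log units; beyond the scatter).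

Compound 4 `CCOc1ccc(C(=O)NC(=N)NCCCCc2ccccc2)cc1` differs from compound 1 by ethoxy in place of methyl on an aromatic carbon. Going by the values given here, no measured step changes a substituent on that aromatic ring while keeping the rest of the molecule fixed. Among the compounds with values here, the only step that touches the aryl group on the carbonyl carbon is the exchange for 2,6-dichlorophenyl in compound 3, which gave a modest loss beyond the scatter; it replaces the whole ring and does not directly inform an ethoxy-for-methyl swap. The step from compound 1 to compound 2, on the chain, is within the scatter and bears on nothing here.

Within the data shown here, with no guiding step, compound 4 is expected to stay close to compound 1, the estimated step being a 1.3-fold higher number from compound 1 to compound 4 (0.12 log units; within the scatter). The estimate for compound 4 in this assay is 1500 nM, with a range from 500 nM to 4500 nM.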

Compound 4, half-maximal inhibitory concentration: 760 nM
Compound 4: middle estimate off by 2.0-fold (0.30 log units), on the high side, within the range that was stated.
By their numbers in this assay, from the lowest: compounds 4, 1 and 2 (each within the scatter of the next, the first and the last beyond it); then compound 3.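

In this assay ethoxy in place of methyl on an aromatic carbon, para to a large group, gives a 1.5-fold lower number from compound 1 to compound 4 (0.18 log units; within the scatter), so compound 1 and compound 4 cannot be ordered. The position therefore accepts ethoxy, with 3 heavy atoms and a hydrogen-bond acceptor against 1 heavy atom for methyl, without a step beyond the scatter, whereas exchange of the whole aryl group gave a 4.4-fold higher number from compound 1 to compound 3 (0.64 log units; beyond the scatter) and did go beyond it. Nothing at hand accounts for this result.

As far as these compounds go, whether an amine, a carboxylic acid or a longer alkoxy chain such as butoxy would also be accepted at this position remains open. Also open, from the compounds shown here alone, is whether ethoxy reads the same way on the longer chain of compound 2.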